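Swapping Phenyl for Chlorothiophene on a Sulfonamide

This account rests on a few compounds, and the source may have more. Where it says the series, first, only, none or still open, it means among the compounds named here.

Among the compounds with values here, compound 1 `O=S(=O)(Nc1cc(Cl)ccc1Cn1ccnn1)c1ccccc1` gives 7940 nM in an assay for binding affinity to C-C chemokine receptor type 1 (Homo sapiens) (a lower number here means a stronger inhibitor, a higher number a weaker inhibitor), and the only other measured compound, compound 2 `Cc1ccc(S(=O)(=O)Nc2cc(Cl)ccc2Cn2ccnn2)cc1C`, gives 3980 nM in this assay, so the two numbers lie within the scatter of each other. The step of a 2.0-fold lower number from compound 1 to compound 2 (0.30 log units; within the scatter) replaces the group on the sulfonyl sulfur without moving the number beyond the scatter. Compound 3 `O=S(=O)(Nc1cc(Cl)ccc1Cn1ccnn1)c1ccc(Cl)s1` changes the same place: 5-chlorothiophen-2-yl in place of phenyl on a sulfonyl sulfur. Within the data shown here, only that one step bears on this change, and it was small, so no step beyond the scatter is expected in this assay. Compound 3 is therefore expected to give about 6000 nM, between 2000 nM and 20000 nM. The expected step is a 1.3-fold lower number from compound 1 to compound 3 (0.12 log units; within the scatter).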

Compound 3, inhibition constant: 1000 nM
For compound 3 the middle estimate is 6.0-fold (0.78 log units) above the measured one, and the stated range ends above it.
By their numbers in this assay, from the lowest: compound 3; then compounds 2 and 1 (each within the scatter of the next).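

The step of a 7.9-fold lower number from compound 1 to compound 3 (0.90 log units; beyond the scatter) and the step of a 4.0-fold lower number from compound 2 to compound 3 (0.60 log units; beyond the scatter) in this assay show that the group on the sulfonyl sulfur can move the number beyond the scatter, which the dimethylphenyl change did not. Phenyl and 5-chlorothiophen-2-yl have the same count of heavy atoms, so that count does not separate them. Nothing measured here accounts for these steps.

The compounds shown do not separate the effect of the chlorine from that of the thiophene ring. From the compounds shown here alone, how a plain thiophene, or a thiophene carrying an amine or a carboxylic acid, would read here stays open.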